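Extending Compound 3 with a Chloro Group

The compounds below may be only part of what the source reports. "The series", "measured", "known", "first", "only" and "open" are said of these compounds alone.

Three compounds built on a shared core have been examined in a functional assay on Jurkat cells (Homo sapiens) for activation, with a stated time of 24 h; on this read-out lower numbers stand for an effect already at smaller amounts and higher numbers for an effect only at larger amounts of compound. Compound 1 `Oc1ccccc1CNc1ccccc1`, the smallest of them, is recorded in this assay as "not active" (no number reported). Compound 2 `Oc1ccccc1CNc1ccc(-c2ccccc2)c(F)c1` gives 2850 nM in this assay, and compound 3 `Oc1ccccc1CNc1ccc(-c2ccccc2)nc1` gives 840 nM. Of the two compounds with a number, compound 3 has the lower one, and the gap between compound 2 and compound 3 lies beyond the usual scatter; compound 1 contributes no number for comparison.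

Compound 4 `Oc1ccccc1CNc1ccc(-c2ccc(Cl)cc2)nc1` is the next compound to be measured. Relative to compound 3 its difference is chloro in place of hydrogen on an aromatic carbon, in words chloro in place of hydrogen on an aromatic carbon, sitting para to a large group; cut one bond further out the change reads phenyl to 4-chlorophenyl. Within the data shown here, no measured pair in this set isolates such a change, so the size of the step rests on judgement alone. In this assay the step of a 1.7-fold lower number from compound 3 to compound 4 (0.23 log units; within the scatter) is expected to be small, leaning toward a lower number but possibly staying within the scatter. Compound 4 is therefore estimated at 500 nM in this assay, with a range from 150 nM to 1500 nM.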

Compound 4, half-maximal effective concentration: "not active" (no number reported)
Nothing numeric was reported for compound 4; no gap can be computed for the estimate.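

In this assay, among these compounds, compound 3 gives 840 nM and compound 4 is recorded as "not active" (no number reported) in the same read-out, so no step between them can be read. The compounds shown leave open what size of change, in number, goes with phenyl to 4-chlorophenyl on the shared core. No other data shown here bear on this result.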